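Sulfonyl sulfur substituents: from compound 2 to compound 3

The source may hold more compounds than are shown below. What is called first, only, known or untested is meant among the compounds shown, and "the series" means these compounds.

Going by the values given here, in a physicochemical assay for solubility, read by spectrophotometry, measured as kinetic solubility, at pH 8, tested at 500 uM (on this read-out higher numbers stand for higher solubility and lower numbers for lower solubility), compound 2 `Cn1ccc2ccc(-c3cc(Nc4ccccc4S(=O)(=O)N4CCOCC4)cc4nccnc34)cc21` gives 5 ug/mL, the lower of the two numbers so far, and compound 1 `CN1CCC(CNS(=O)(=O)c2ccccc2Nc2cc(-c3ccc4ccn(C)c4c3)c3nccnc3c2)C1` gives 35 ug/mL. Compound 3 `CN(Cc1cncnc1)S(=O)(=O)c1ccccc1Nc1cc(-c2ccc3ccn(C)c3c2)c2nccnc2c1` carries methyl((pyrimidin-5-yl)methyl)amino in place of morpholin-4-yl on a sulfonyl sulfur. Among the compounds with values here, the only measured step at this place, a 7.0-fold lower number from compound 1 to compound 2 (0.85 log units; beyond the scatter), lies beyond the scatter but starts from a different group, so it gives only a loose guide. In this assay no step beyond the scatter is expected, and the estimated step is a 1.6-fold higher number from compound 2 to compound 3 (0.20 log units; within the scatter). The estimate for compound 3 is 8 ug/mL, with an expected range of 2.5 ug/mL to 28 ug/mL.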

Compound 3, solubility: 3 ug/mL
For compound 3 the middle estimate is 2.7-fold (0.43 log units) above the measured one, within the range that was stated.
By their numbers in this assay, from the lowest: compounds 3 and 2 (each within the scatter of the next); then compound 1.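

In this assay, methyl((pyrimidin-5-yl)methyl)amino in place of morpholin-4-yl on a sulfonyl sulfur gives a 1.7-fold lower number from compound 2 to compound 3 (0.22 log units; within the scatter) and so does not separate the two groups, even with a six-membered aromatic ring entering. Only ((1-methylpyrrolidin-3-yl)methyl)amino stands apart so far, with a 12-fold lower number from compound 1 to compound 3 (1.07 log units; beyond the scatter) for this second exchange. No measurement available here explains the difference.

Open, on these data alone, is whether an open-chain group such as (2-(dimethylamino)ethyl)amino on the sulfonyl sulfur would give a number like that of compound 1, or whether the pyrrolidine ring is needed.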